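Moving the Thiophene Attachment Point on the Shared Core

A few compounds are considered here, and "the series" means these few. Any claim that something is new, unique, unknown or untested is made for them only; others in the source may bear on it.

Two compounds of this series have numbers in a functional assay on T47D cells (Homo sapiens) for cytotoxicity, read by CCK-8 assay and cell counting, with a stated time of 2 days (a lower number here means a stronger inhibitor, a higher number a weaker inhibitor), so far. Compound 1 `Oc1cccc(-c2cc(-c3ccc(Cl)cc3)nc(-c3cccs3)c2)c1` gives 10500 nM, while compound 2 `Oc1cccc(-c2cc(-c3ccsc3)nc(-c3cccc(Cl)c3)c2)c1` gives 3540 nM, the lowest of the two numbers; compound 1, its nearest neighbour, sits at a higher number by a step beyond the scatter. Compound 3 `Oc1cccc(-c2cc(-c3cccc(Cl)c3)nc(-c3cccs3)c2)c1` holds the same atoms as compound 2, joined differently: thiophen-2-yl in place of thiophen-3-yl on an aromatic carbon. For the measured compounds named here, no measured pair shows this change on its own. The step of a 1.4-fold higher number from compound 2 to compound 3 (0.15 log units; within the scatter) is expected to be small, drifting somewhat toward a higher number. Compound 3 is therefore estimated at 5000 nM, within 2000 nM to 13000 nM.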

Compound 3, half-maximal inhibitory concentration: 3410 nM
For compound 3 the middle estimate is 1.5-fold (0.17 log units) above the measured one; measured number inside the range.
By their numbers in this assay, from the lowest: compounds 3 and 2 (each within the scatter of the next); then compound 1.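

On the aromatic carbon next to the ring nitrogen, thiophen-2-yl in place of thiophen-3-yl gives a 1.0-fold lower number from compound 2 to compound 3 (0.02 log units; within the scatter) in this assay, so the thiophene attachment point does not separate these two compounds. Moving the chlorine does separate compounds: 3-chlorophenyl in place of 4-chlorophenyl gives a 3.1-fold lower number from compound 1 to compound 3 (0.49 log units; beyond the scatter), a modest step. No supporting measurement accounts for either step. The compounds shown leave open whether the thiophene attachment point would matter as little alongside 4-chlorophenyl. They also leave open what an amine or a carboxylic acid in place of the thiophene would give.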